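A few compounds are considered here, and "the series" means these few. Any claim that something is new, unique, unknown or untested is made for them only; others in the source may bear on it.

The three measured compounds:

Compound 1, `O=C(CCCCC[C@H](NC(=O)OCc1ccccc1)C(=O)NCc1ccccc1)NO`, gives 1520 nM in a functional assay on NFF cells (Homo sapiens) for antiproliferative activity; a lower number here means a stronger inhibitor, a higher number a weaker inhibitor.
Compound 2, `CN(C)c1ccc(NC(=O)[C@H](CCCCCC(=O)NO)NC(=O)OCc2ccccc2)cc1`, gives 650 nM in this assay.
Compound 3, `O=C(CCCCC[C@H](NC(=O)OCc1ccccc1)C(=O)Nc1ccc(-c2ccccc2)cc1)NO`, gives 2200 nM in this assay.

Compound 3 has the highest number of the three. Against compound 1 the gap is small and stays within the scatter: a 1.4-fold higher number from compound 1 to compound 3 (0.16 log units; within the scatter). Against compound 2 it is wider and lies beyond the scatter: a 3.4-fold higher number from compound 2 to compound 3 (0.53 log units; beyond the scatter). The remaining measured step runs the other way: a 2.3-fold lower number from compound 1 to compound 2 (0.37 log units; beyond the scatter). All three measured steps vary only the group on the amide-type nitrogen, and every measured compound carries the same benzyloxycarbonyl group on the other nitrogen.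

Compound 4, `O=C(CCCCC[C@H](NC(=O)c1ccc(Br)cc1)C(=O)Nc1ccc(-c2ccccc2)cc1)NO`, keeps the 4-phenylphenyl amide of compound 3 and changes that benzyloxycarbonyl end instead: 4-bromophenyl in place of benzyloxy on a carbonyl carbon. Going by the values given here, no measured step touches this part of the molecule, so nothing among the measured compounds shows which way such a change moves the number, or whether it moves it at all. Among the compounds with values here, the only anchor is the value of compound 3 itself.

Compound 4 is therefore expected to give roughly 2000 nM in this assay, with a range from 600 nM to 7000 nM. The step this estimate implies, a 1.1-fold lower number from compound 3 to compound 4 (0.04 log units; within the scatter), is expected to stay within the scatter, with a wider uncertainty than usual.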

Compound 4, half-maximal inhibitory concentration: 190 nM
The estimate for compound 4 lay 11-fold (1.02 log units) above the measured number; measured number below the stated range.
By their numbers in this assay, from the lowest: compound 4; then compound 2; then compounds 1 and 3 (each within the scatter of the next).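

The result shows that the group on the carbonyl carbon of the other nitrogen, identical across compounds 1 to 3, has a strong bearing on the number in this assay. With the 4-phenylphenyl amide held fixed, 4-bromophenyl in place of benzyloxy gives a 12-fold lower number from compound 3 to compound 4 (1.06 log units; beyond the scatter), a larger change than the widest step seen on the amide-type nitrogen, which is a 3.4-fold higher number from compound 2 to compound 3 (0.53 log units; beyond the scatter), so this end of the molecule can move the number further than any amide change shown. Nothing available explains why this exchange of benzyloxycarbonyl for (4-bromophenyl)carbonyl has so large an effect.

The compounds shown leave open whether the same exchange would lower the number to a similar extent with the benzyl amide of compound 1 or the 4-(dimethylamino)phenyl amide of compound 2, since the 4-bromophenyl group appears here only with the 4-phenylphenyl amide. They also leave open how much of the step belongs to the bromine itself and how much to the loss of the benzyloxy group, a question that an unsubstituted phenyl, a 4-chlorophenyl or a 4-aminophenyl on the same carbonyl carbon would address.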